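This account rests on a few compounds, and the source may have more. Where it says the series, first, only, none or still open, it means among the compounds named here.

In a functional assay on MDA-MB-231 cells (Homo sapiens) for antiproliferative activity, read by MTT assay, with a stated time of 72 h (on this read-out higher numbers stand for weaker inhibition and lower numbers for stronger inhibition), compound 1 `O=C(CCc1cccc2c1B(O)OC2)NCc1ccccc1` gives only a limit, > 100000 nM, as noted by the limit of > 100000 nM in this assay, at which 1 of the 2 values shown sits. Compound 2 `C#Cc1ccc(NC(=O)CCc2cccc3c2B(O)OC3)cc1` gives 6600 nM in this assay. Compound 3 `O=C(CCc1cccc2c1B(O)OC2)Nc1cccc(I)c1` has not yet been measured in this assay; it differs from compound 1 by 3-iodophenyl in place of benzyl on an amide-type nitrogen. For the measured compounds named here, no measured pair shares exactly this change, so no step is known for it. Because compound 2, which also has a ring on its amide-type nitrogen, reaches 6600 nM, a step toward stronger inhibition is expected an at least 8.3-fold lower number from compound 1 to compound 3 (0.92 log units; beyond the scatter). Compound 3 is therefore estimated at 12000 nM in this assay, between 3000 nM and 50000 nM.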

Compound 3, half-maximal inhibitory concentration: 5300 nM
For compound 3 the middle estimate is 2.3-fold (0.35 log units) above the measured one, within the range that was stated.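

At the amide-type nitrogen, 3-iodophenyl in place of benzyl gives an at least 18-fold lower number from compound 1 to compound 3 (1.27 log units; beyond the scatter) in this assay. Both groups have the same heavy-atom count and one six-membered aromatic ring of carbon only, so that count alone does not separate them. The size of this step is bounded by a limit, not a number, for compound 1: the limit of > 100000 nM in this assay, at which 1 of the 3 values shown sits.

The compounds shown leave open whether the iodine or the change from benzyl to a phenyl ring carries this step. They also leave open how an unsubstituted phenyl group or a ring bearing a carboxylic acid would read.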